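The source may hold more compounds than are shown below. What is called first, only, known or untested is meant among the compounds shown, and "the series" means these compounds.

In a functional assay on FM3A cells (Mus musculus) for antiproliferative activity (a higher number here means a weaker inhibitor, a lower number a stronger inhibitor), compound 1 `COc1cc(C(=O)c2sc(-c3ccc(C)cc3)cc2N)cc(OC)c1OC` gives 16 nM, compound 2 `COc1cc(C(=O)c2sc(-c3ccc(Cl)cc3)cc2N)cc(OC)c1OC` gives 90 nM and compound 3 `COc1cc(C(=O)c2sc(-c3ccc(C(F)(F)F)cc3)cc2N)cc(OC)c1OC` gives 540 nM, the highest of the three. Compound 4 `CCOc1ccc(-c2cc(N)c(C(=O)c3cc(OC)c(OC)c(OC)c3)s2)cc1` differs from compound 3 by ethoxy in place of trifluoromethyl on an aromatic carbon. Among the compounds with values here, no measured step swaps in an ethoxy, but two steps show what removing a trifluoromethyl in the same place is worth: going the other way, from compound 3 a 34-fold higher number from compound 1 to compound 3 (1.53 log units; beyond the scatter) and a 6.0-fold higher number from compound 2 to compound 3 (0.78 log units; beyond the scatter). Replacing trifluoromethyl is therefore expected to lower the number markedly, and compound 4 is expected to sit nearer compound 1 than compound 3, giving a 15-fold lower number from compound 3 to compound 4 (1.19 log units; beyond the scatter). The estimate for compound 4 in this assay is 35 nM, within a range from 10 nM to 130 nM.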

Compound 4, half-maximal inhibitory concentration: 510 nM
Compound 4: middle estimate off by 15-fold (1.16 log units), on the low side; the whole stated range lies below it.
By their numbers in this assay, from the lowest: compound 1; then compound 2; then compounds 4 and 3 (each within the scatter of the next).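

In this assay, swapping trifluoromethyl for ethoxy at this place changes nothing that can be read, with a 1.1-fold lower number from compound 3 to compound 4 (0.02 log units; within the scatter), a difference within the scatter. Ethoxy therefore stays well short of the two lower numbers, with a 5.7-fold higher number from compound 2 to compound 4 (0.75 log units; beyond the scatter) and a 32-fold higher number from compound 1 to compound 4 (1.50 log units; beyond the scatter), so removing trifluoromethyl does not by itself lower the number. No measurement shown explains why these two different groups give matching results. As far as these compounds go, whether a methoxy group, a hydroxyl or an amine here would come closer to compound 1 remains open. So does whether a longer chain than ethoxy would raise the number further.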